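Ethylamino to 3-fluorobenzylamino: what to expect for compound 4

This account rests on a few compounds, and the source may have more. Where it says the series, first, only, none or still open, it means among the compounds named here.

Within the data shown here, compound 3, `CCCCC#Cc1nc(NCC)c2ncn([C@H]3[C@H](O)[C@H](O)[C@@H]4C[C@@H]43)c2n1`, is one of three compounds measured in an assay on CHO cells for displacement of a labelled ligand from adenosine receptor A1 (Homo sapiens), read by scintillation counting, with a stated time of 60 min, tested at 10 uM (a higher number here means more inhibition at the concentration tested (going by the name of the read-out), a lower number less inhibition), where compound 3 gives 31%. Its neighbours carry a halogenated benzyl group on the same nitrogen: compound 1, `CCCCC#Cc1nc(NCc2cccc(Br)c2)c2ncn([C@H]3[C@H](O)[C@H](O)[C@@H]4C[C@@H]43)c2n1`, gives 38%, and compound 2, `CCCCC#Cc1nc(NCc2cccc(Cl)c2)c2ncn([C@H]3[C@H](O)[C@H](O)[C@@H]4C[C@@H]43)c2n1`, gives 19%. Compound 3 therefore sits between them, on a par with compound 1, since a number 7 percentage points lower from compound 1 to compound 3 (within the scatter), but above compound 2, since a number 12 percentage points higher from compound 2 to compound 3 (beyond the scatter). Between the two halogenated compounds themselves, a number 19 percentage points lower from compound 1 to compound 2 (beyond the scatter).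

Compound 4, `CCCCC#Cc1nc(NCc2cccc(F)c2)c2ncn([C@H]3[C@H](O)[C@H](O)[C@@H]4C[C@@H]43)c2n1`, differs from compound 3 by 3-fluorophenyl in place of methyl on a saturated chain carbon bound to a nitrogen on an aromatic ring. The two steps from compound 1 and compound 2 to compound 3 bear directly on this change: replacing the 3-halophenyl by methyl was neutral in one case and a modest gain in the other, so the reverse change is expected to be neutral or a modest loss, with a number 6 percentage points lower from compound 3 to compound 4 (within the scatter) as the anticipated step. Compound 4 is thus estimated at 25%, with a range from 10% to 40%.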

Compound 4, a percentage reported as inhibition, at one concentration (the size of the read-out at that concentration, not a potency): 21%
Beside the measured number, compound 4's estimate is 4 percentage points above it; the measured number falls inside the stated range.
By their numbers in this assay, from the lowest: compounds 2, 4, 3 and 1 (each within the scatter of the next, the first and the last beyond it).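

In this assay the exchange of methyl for 3-fluorophenyl (a number 10 percentage points lower from compound 3 to compound 4 (within the scatter)) stays within the scatter, as the same exchange does for the bromo compound 1 but not for the chloro compound 2. Fluoro and chloro on the aromatic carbon cannot be told apart (a number 2 percentage points higher from compound 2 to compound 4 (within the scatter)), whereas fluoro in place of bromo gives a separation beyond the scatter (a number 17 percentage points lower from compound 1 to compound 4 (beyond the scatter)). With a third halogen in hand, bromo in compound 1 stands apart from both other halogens, a picture that compound 2 alone could not establish.

As far as these compounds go, what a methoxy or hydroxyl group on the phenyl ring, or a chain longer than ethyl on the nitrogen, would give remains open. Nothing available here accounts for the separation of bromo from the other halogens.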